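The compounds below may be only part of what the source reports. "The series", "measured", "known", "first", "only" and "open" are said of these compounds alone.

In an ADME assay on MOLT-3 cells (Homo sapiens) for cytotoxicity, with a stated time of 7 days (a higher number here means that more compound is tolerated, a lower number that less compound is tolerated), compound 1, `CCCSc1nc(N)nc2c1ncn2/C=C1/CC1(CO)CO`, gives only the assay limit > 20000 nM.
In this assay compound 2, `CSc1nc(N)nc2c1ncn2/C=C1/CC1(CO)CO`, gives only the assay limit > 20000 nM.
In this assay compound 3, `CCCCCCOc1nc(N)nc2c1ncn2/C=C1/CC1(CO)CO`, gives only the assay limit > 20000 nM.

Compound 1 and compound 2 share one core and differ by hydrogen in place of ethyl on a saturated chain carbon bound to a sulfur. The step between them in this assay is a step that the two limits leave unreadable from compound 1 to compound 2, so its size stays hidden, because of the limit of > 20000 nM in this assay, at which 3 of the 3 values shown sit. Among the compounds with values here, compound 4, `CCCCOc1nc(N)nc2c1ncn2/C=C1/CC1(CO)CO`, is made from compound 3 by hydrogen in place of ethyl on a saturated chain carbon, four bonds along the chain from an oxygen on an aromatic ring, a change of the same kind as the one from compound 1 to compound 2, though here the saturated chain carbon sits four bonds along the chain from an oxygen on an aromatic ring rather than bound to a sulfur. The two cores differ by hexyloxy in place of propylsulfanyl on an aromatic carbon. Since compound 3 itself reaches only the limit, and the same kind of change between compound 1 and compound 2 left both at the limit, the step from compound 3 to compound 4 in this assay is expected to be a step that the limit leaves unreadable from compound 3 to compound 4. Compound 4 is therefore estimated at 40000 nM, most likely again reported only as a limit.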

Compound 4, half-maximal cytotoxic concentration: > 20000 nM
Compound 4: only a limit was reported (the forecaster's own chance of this, stated with the estimate: 85%); the middle value does not contradict the limit.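

Compound 4, like compound 1, compound 2 and compound 3, gives only a limit in this assay, so none of its steps to those three compounds can be read, because every value sits at the same limit: the limit of > 20000 nM in this assay, at which 4 of the 4 values shown sit.

The compounds shown leave open whether any of these chains on the shared core changes cytotoxicity at all.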